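Series notes: compound 3 to compound 4

The compounds below may be only part of what the source reports. "The series", "measured", "known", "first", "only" and "open" are said of these compounds alone.

Compound 3 `CCCCN/C(=C1/N=CN(CCOC)C1=O)c1cc2ccccc2[nH]1` gives 350 nM in an assay on isolated protein for inhibition of Calpain-1 catalytic subunit (Homo sapiens), read by fluorescence, with a stated time of 60 min (on this read-out higher numbers stand for weaker inhibition and lower numbers for stronger inhibition), the lowest of the two numbers shown. Compound 1 `COCCN/C(=C1/N=CN(CCOC)C1=O)c1cc2ccccc2[nH]1` gives 460 nM in this assay, and the step of a 1.3-fold lower number from compound 1 to compound 3 (0.12 log units; within the scatter) stays within the scatter. Compound 2 `CC(C)N/C(=C1/N=CN(C(C)C)C1=O)c1cc2ccccc2[nH]1` gives > 1000 nM in this assay, which is a limit of > 1000 nM in this assay, at which 1 of the 3 values shown sits, and not a number. Compound 4 `COCCN1C=N/C(=C(/NCCN(C)C)c2cc3ccccc3[nH]2)C1=O` differs from compound 3 by dimethylamino in place of ethyl on a saturated chain carbon, two bonds along the chain from an amine nitrogen. Within the data shown here, the only measured step at this place, a 1.3-fold lower number from compound 1 to compound 3 (0.12 log units; within the scatter), was within the scatter, so no step beyond the scatter is expected here either, though a dimethylamino group has no measured precedent. For compound 4 the expected value in this assay is 400 nM, between 150 nM and 1200 nM. This estimate means a step of a 1.1-fold higher number from compound 3 to compound 4 (0.06 log units; within the scatter), expected to remain within the scatter.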

Compound 4, half-maximal inhibitory concentration: > 1000 nM
Compound 4 ended at the assay's limit; the forecaster's own chance of this, stated with the estimate: 15%; at least 2.5-fold (0.39 log units) between middle value and limit.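

This place on the chain is not indifferent to the group it carries: in this assay the change to dimethylamino gives an at least 2.8-fold higher number from compound 3 to compound 4 (0.45 log units; beyond the scatter) and an at least 2.1-fold higher number from compound 1 to compound 4 (0.33 log units; beyond the scatter), while the earlier ethyl and methoxy pair stayed within the scatter at a 1.3-fold lower number from compound 1 to compound 3 (0.12 log units; within the scatter). The value of compound 4 is a limit and not a number: the limit of > 1000 nM in this assay, at which 2 of the 4 values shown sit.

From the compounds shown here alone, the full size of both steps stays open. Also open, going by these compounds, is whether a primary amine, a carboxylic acid or a longer alkyl chain at this place would behave like dimethylamino or like ethyl.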